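The source may hold more compounds than are shown below. What is called first, only, known or untested is meant among the compounds shown, and "the series" means these compounds.

Working notes on the series. The shared core of compound 1 `O=C(NCc1cc(Cl)ccc1-n1cnnn1)[C@@H]1C[C@@H]2C[C@@H]2N1C(=O)[C@H](O)Cc1ccccn1` carries different groups on the saturated chain carbon beside the hydroxyl; in a functional assay on a cell-free system (plasma, Homo sapiens), with a stated time of 3 min (on this read-out lower numbers stand for stronger inhibition and higher numbers for weaker inhibition), compound 1 gives 1000 nM. Compound 2 `CC1(C[C@@H](O)C(=O)N2C[C@H]3C[C@H]3[C@H]2C(=O)NCc2cc(Cl)ccc2-n2cnnn2)CC1` gives 500 nM in this assay. Compound 3 `O=C(NCc1cc(Cl)ccc1-n1cnnn1)[C@@H]1CC=NN1C(=O)[C@H](O)c1ccccc1F` gives 1100 nM, the highest of the three numbers; the gap to compound 1 lies within the scatter, so the two are not separated, while compound 2 gives a number beyond the scatter below that of compound 3.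

Compound 4 `CC(C)(C)OC[C@@H](O)C(=O)N1N=CC[C@H]1C(=O)NCc1cc(Cl)ccc1-n1cnnn1` is not yet measured. It differs from compound 3 in one place: (tert-butoxy)methyl in place of 2-fluorophenyl on a saturated chain carbon bound to a carbonyl carbon and an oxygen on a saturated carbon. Going by the values given here, no measured pair isolates this change. Among the compounds with values here, the only guide is that compound 2, whose group at the same place is saturated and without a ring there, gives 500 nM, whereas compound 3 with an aromatic group gives 1100 nM; compound 1 with a heteroaromatic group sits between them within the scatter of compound 3.

The expected step of a 1.6-fold lower number from compound 3 to compound 4 (0.20 log units; within the scatter) is therefore small, toward a lower number, and may not exceed the scatter. Compound 4 is estimated at 700 nM, with a range from 250 nM to 2000 nM; the expectation rests on compound 2 giving 500 nM.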

Compound 4, half-maximal inhibitory concentration: 750 nM
Compound 4: the middle estimate sits 1.1-fold (0.03 log units) below what was measured, within the range that was stated.
By their numbers in this assay, from the lowest: compounds 2, 4, 1 and 3 (each within the scatter of the next, the first and the last beyond it).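

In this assay, (tert-butoxy)methyl in place of 2-fluorophenyl on a saturated chain carbon bound to a carbonyl carbon and an oxygen on a saturated carbon gives a 1.5-fold lower number from compound 3 to compound 4 (0.17 log units; within the scatter). Going by these compounds alone, this is the first pair that isolates a change at this place, and it shows that the six-membered aromatic ring of carbon only can be exchanged for a group with no ring and with a hydrogen-bond acceptor without separating the two compounds on this read-out. No measurement at hand bears on why the step is this small, so the result stands as an observation only.

From the compounds shown here alone, with a single step at this place, it remains open whether any group there can move the number beyond the scatter on this core, and one pair cannot show whether the ring or the oxygen of the entering group matters on its own. A primary amine or a carboxylic acid at the end of the chain would test a charged group at this place, which neither member of the pair carries.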